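Pyrrolidinyl in place of ethyl on the core nitrogen

The source may report more compounds than this note shows. Statements on the series, on what has been measured and on what is new or still open speak of the compounds shown alone.

Compound 1, `CCn1nc(CC(=O)Nc2ccc(OC(F)(F)F)c(Cl)c2)c2ccccc2c1=O`, gives 199 nM in a functional assay on CHO cells for antagonist activity at sphingosine 1-phosphate receptor 2 (Homo sapiens), read by calcium flux; on this read-out lower numbers stand for stronger inhibition and higher numbers for weaker inhibition.
Compound 2, `COC(C(=O)O)c1nn(Cc2cn3cc(OCC4CC4)c(Cl)cc3n2)c2ccccc2c1=O`, gives 23 nM in this assay.
Compound 3, `COc1ccc(NC(=O)Cc2nn(CC(=O)O)c(=O)c3ccccc23)c(OC)c1`, reaches only the assay limit of > 19900 nM in this assay.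

Of the two numbers recorded, compound 1 stands at the higher one and compound 2 at the lower. Compound 3 sits at the limit of > 19900 nM in this assay, at which 1 of the 3 values shown sits. Compound 4, `O=C(Cc1nn(C2CCNC2)c(=O)c2ccccc12)Nc1ccc(OC(F)(F)F)c(Cl)c1`, differs from compound 1 by pyrrolidin-3-yl in place of ethyl on an aromatic nitrogen. For the measured compounds named here, no measured pair isolates this change, so the expected step from compound 1 to compound 4 in this assay is a 1.7-fold lower number from compound 1 to compound 4 (0.22 log units; within the scatter), a small gain that may not exceed the scatter. Compound 4 is therefore estimated at 120 nM in this assay, with a range from 30 nM to 500 nM.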

Compound 4, half-maximal inhibitory concentration: 94 nM
Estimate against measurement, compound 4: 1.3-fold (0.11 log units) above, within the range that was stated.
By their numbers in this assay, from the lowest: compound 2; then compound 4; then compound 1. At a limit, above all of these: compound 3.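

In this assay, the aromatic nitrogen of the core takes pyrrolidin-3-yl in place of ethyl with a 2.1-fold lower number from compound 1 to compound 4 (0.33 log units; beyond the scatter) and so tolerates a larger group, a non-aromatic ring carrying a hydrogen-bond donor, with a modest gain. This is the first comparison among the compounds shown that isolates a change at this position. Nothing shown here gives a cause for this step.

On these data alone, it remains open whether the ring or its nitrogen carries the step, which cyclopentyl on the same nitrogen would separate. As far as these compounds go, whether an open-chain aminoethyl group would serve equally also stays open.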